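Phenyl in place of branched alkyl at the chain carbon

The compounds below may be only part of what the source reports. "The series", "measured", "known", "first", "only" and "open" are said of these compounds alone.

Among the compounds with values here, in an in vitro functional assay on cells for agonist activity at Bombesin receptor subtype-3 (Mus musculus), read by luminescence and calcium flux (on this read-out lower numbers stand for an effect already at smaller amounts and higher numbers for an effect only at larger amounts of compound), compound 3 `CCC(C)(CC)Cc1cnc(CCc2ccc(-c3ccccc3C(=O)O)cc2)[nH]1` gives 30 nM, the second highest of the three numbers measured so far; compound 1 `O=C(O)c1ccccc1-c1ccc(CCc2ncc(Cc3cccc(F)c3)[nH]2)cc1` gives 7.9 nM and compound 2 `O=C(O)c1ccccc1-c1ccc(CCc2ncc(CCc3ccccc3)[nH]2)cc1` gives 174 nM. Compound 4 `O=C(O)c1ccccc1-c1ccc(CCc2ncc(Cc3ccccc3)[nH]2)cc1` is not yet measured; relative to compound 3 it carries phenyl in place of 1-ethyl-1-methylpropyl on a saturated chain carbon bound to an aromatic carbon. Within the data shown here, two measured steps bear on this change: a 3.8-fold higher number from compound 1 to compound 3 (0.58 log units; beyond the scatter), and a 5.8-fold lower number from compound 2 to compound 3 (0.76 log units; beyond the scatter). The phenyl of compound 4 lacks the fluorine of compound 1 and the extra chain carbon of compound 2, so a modest move toward a lower number, or none beyond the scatter, is the reading. The number expected for compound 4 is therefore 20 nM, within 6 nM to 70 nM. This amounts to an expected 1.5-fold lower number from compound 3 to compound 4 (0.18 log units; within the scatter).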

Compound 4, half-maximal effective concentration: 11 nM
For compound 4 the middle estimate is 1.8-fold (0.26 log units) above the measured one, within the range that was stated.
By their numbers in this assay, from the lowest: compounds 1 and 4 (each within the scatter of the next); then compound 3; then compound 2.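

In this assay, phenyl and 1-ethyl-1-methylpropyl have the same heavy-atom count, yet the swap gives a 2.7-fold lower number from compound 3 to compound 4 (0.44 log units; beyond the scatter), so a ring at this chain carbon does better than this branched alkyl group. Benzyl to phenyl gives a 16-fold lower number from compound 2 to compound 4 (1.20 log units; beyond the scatter), so the single extra chain carbon accounts for a large change on its own. Removing the fluoro gives a 1.4-fold higher number from compound 1 to compound 4 (0.14 log units; within the scatter), so the large gap between compound 1 and compound 2 follows the chain length and not the fluoro.

From the compounds shown here alone, whether a cyclohexyl group or a pyridine ring on the same chain carbon would match phenyl remains open. Nothing available explains any of these steps.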